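Moving away from 4-hydroxyphenyl in the lowest-scoring compound

The source may hold more compounds than are shown below. What is called first, only, known or untested is meant among the compounds shown, and "the series" means these compounds.

In an ADME assay on PC-12 cells (Rattus norvegicus) for cytotoxicity, read by WST assay, with a stated time of 24 h (on this read-out higher numbers stand for lower toxicity in this test and lower numbers for higher toxicity in this test), compound 1 (`O=C(/C=C/c1cccc(O)c1O)CC(=O)/C=C/c1cccc(O)c1O`) gives 39000 nM and compound 2 (`O=C(/C=C/c1ccccc1O)CC(=O)/C=C/c1cccc(O)c1O`) gives 34000 nM while the step of a 1.1-fold lower number from compound 1 to compound 2 (0.06 log units; within the scatter) stays within the scatter. Compound 3 (`O=C(/C=C/c1ccc(O)cc1)CC(=O)/C=C/c1cccc(O)c1O`) stands lowest at 8500 nM and is thus the most toxic of the three compounds measured. Both a 4.6-fold lower number from compound 1 to compound 3 (0.66 log units; beyond the scatter) and a 4.0-fold lower number from compound 2 to compound 3 (0.60 log units; beyond the scatter) are modest steps beyond the scatter, and both end in the 4-hydroxyphenyl group. Compound 4 (`O=C(/C=C/c1cc(O)ccc1O)CC(=O)/C=C/c1cccc(O)c1O`) carries 2,5-dihydroxyphenyl in place of 4-hydroxyphenyl on a double-bonded chain carbon bound to a double-bonded chain carbon. Among the measured compounds shown here, no measured compound holds this group, so the evidence is indirect. The two measured compounds without the 4-hydroxyphenyl group give higher numbers, and leaving that group is therefore expected to reverse part of the step of a 4.0-fold lower number from compound 2 to compound 3 (0.60 log units; beyond the scatter) and not all of it. The expected change is a 2.4-fold higher number from compound 3 to compound 4 (0.37 log units; beyond the scatter) toward lower toxicity, with wide uncertainty. In this assay compound 4 is estimated at 20000 nM with a range from 7000 nM to 50000 nM as the expected span of a measurement.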

Compound 4, half-maximal cytotoxic concentration: 53000 nM
Compound 4: middle estimate off by 2.7-fold (0.42 log units), on the low side; measured number outside the range, above it.
By their numbers in this assay, from the lowest: compound 3; then compounds 2, 1 and 4 (each within the scatter of the next).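

In this assay, the change from 4-hydroxyphenyl to 2,5-dihydroxyphenyl does more than partly reverse the earlier drop: a 6.2-fold higher number from compound 3 to compound 4 (0.79 log units; beyond the scatter) is a modest step toward lower toxicity in this test. It brings compound 4 level with the other two compounds, since a 1.6-fold higher number from compound 2 to compound 4 (0.19 log units; within the scatter) and a 1.4-fold higher number from compound 1 to compound 4 (0.13 log units; within the scatter) both stay within the scatter, so 2-hydroxyphenyl, 2,3-dihydroxyphenyl and 2,5-dihydroxyphenyl cannot be told apart at this position. Among these four compounds, only compound 3, with 4-hydroxyphenyl, stands apart from the rest.

Nothing shown explains why this one group goes with the lower number. Going by these compounds, whether an unsubstituted phenyl, a 4-methoxyphenyl or a 4-aminophenyl group at this place would follow compound 3 or compound 4 remains open.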